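Azidomethyl in place of but-1-en-1-yl on a carbonyl carbon

The compounds below may be only part of what the source reports. "The series", "measured", "known", "first", "only" and "open" are said of these compounds alone.

In a functional assay on HCT-116 cells (Homo sapiens) for inhibition, read by MTT assay, with a stated time of 48 h (a lower number here means a stronger inhibitor, a higher number a weaker inhibitor), compound 1 `CCCCC(=O)N(Cc1ccc(OC)c(O)c1)c1cc(OC)c(OC)c(OC)c1` gives 170 nM, compound 2 `CCC/C=C/C(=O)N(Cc1ccc(OC)c(O)c1)c1cc(OC)c(OC)c(OC)c1` gives 95 nM and compound 3 `CC/C=C/C(=O)N(Cc1ccc(OC)c(O)c1)c1cc(OC)c(OC)c(OC)c1` gives 63 nM. Compound 3 thus stands within the scatter of compound 2, and only compound 1 lies apart from it, at a higher number. The three differ only in the chain on a carbonyl carbon. But-1-en-1-yl in place of butyl gave a 2.7-fold lower number from compound 1 to compound 3 (0.43 log units; beyond the scatter), whereas pent-1-en-1-yl in place of butyl gave a 1.8-fold lower number from compound 1 to compound 2 (0.25 log units; within the scatter), and the shortening of the chain gave a 1.5-fold lower number from compound 2 to compound 3 (0.18 log units; within the scatter).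

Compound 4 `COc1ccc(CN(C(=O)CN=[N+]=[N-])c2cc(OC)c(OC)c(OC)c2)cc1O` carries azidomethyl in place of but-1-en-1-yl on a carbonyl carbon. Among the measured compounds shown here, no measured compound carries azidomethyl, so the guide is only partial. The nearest is a 2.7-fold lower number from compound 1 to compound 3 (0.43 log units; beyond the scatter), where but-1-en-1-yl entered. Here it leaves, so a modest step toward a higher number is expected in this assay. The estimated change is a 2.5-fold higher number from compound 3 to compound 4 (0.40 log units; beyond the scatter). The estimate for compound 4 is 160 nM, with an expected range of 45 nM to 550 nM.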

Compound 4, half-maximal inhibitory concentration: 410 nM
Compound 4: the middle estimate sits 2.6-fold (0.41 log units) below what was measured, and the stated range covers the measured number.
By their numbers in this assay, from the lowest: compounds 3, 2 and 1 (each within the scatter of the next, the first and the last beyond it); then compound 4.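

In this assay azidomethyl on the carbonyl carbon gave a 6.5-fold higher number from compound 3 to compound 4 (0.81 log units; beyond the scatter) and a 4.3-fold higher number from compound 2 to compound 4 (0.64 log units; beyond the scatter) and also a 2.4-fold higher number from compound 1 to compound 4 (0.38 log units; beyond the scatter), which leaves compound 4 with the highest number of the four. Thus a change at this position can move the number upward as well as down, and the step from the saturated butyl chain of compound 1 shows that the rise is not confined to comparisons with the chains that carry a double bond. Nothing measured here accounts for this result.

The compounds shown leave open whether the nitrogen atoms of azidomethyl or some other feature of the group sets this number. An aminomethyl or propyl group on the same carbonyl carbon, or a carboxylic acid chain, could help separate these readings.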